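A few compounds are considered here, and "the series" means these few. Any claim that something is new, unique, unknown or untested is made for them only; others in the source may bear on it.

Measured so far:
compound 2 `COc1ccc(/C=C\C(=O)O)c(OCc2cn(-c3ccccc3F)nn2)c1CC=C(C)C` — 11000 nM
compound 3 `COc1cccc(-n2cc(COc3c(/C=C\C(=O)O)ccc(OC)c3CC=C(C)C)nn2)c1` — 20400 nM
compound 1 `COc1ccccc1-n1cc(COc2c(/C=C\C(=O)O)ccc(OC)c2CC=C(C)C)nn1` — "not determined" (no result reported)

The read-out is a functional assay on T47D cells (Homo sapiens) for cytotoxicity, read by MTT assay, with a stated time of 24 h; on this read-out lower numbers stand for stronger inhibition and higher numbers for weaker inhibition. Compound 2 stands at the lower of the two numbers recorded, with compound 3 nearest; the step of a 1.9-fold higher number from compound 2 to compound 3 (0.27 log units; within the scatter) lies within the scatter. Compound 1 has no result in this assay.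

Compound 4 is `COc1ccc(/C=C\C(=O)O)c(OCc2cn(-c3nc4ccccc4s3)nn2)c1CC=C(C)C`. It differs from compound 2 by 1,3-benzothiazol-2-yl in place of 2-fluorophenyl on an aromatic nitrogen. Going by the values given here, only one measured step bears on this place, a 1.9-fold higher number from compound 2 to compound 3 (0.27 log units; within the scatter), which exchanged the group on the same aromatic nitrogen and stayed within the scatter. Among the compounds with values here, no measured step brings a ring with hetero atoms into that position, so the expectation rests on that single step. Compound 4 is therefore expected close to compound 2, with an estimated step of a 1.1-fold higher number from compound 2 to compound 4 (0.04 log units; within the scatter) not beyond the scatter. The estimate for compound 4 is 12000 nM, range 4000 nM to 36000 nM.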

Compound 4, half-maximal inhibitory concentration: 17200 nM
Compound 4: middle estimate off by 1.4-fold (0.16 log units), on the low side; low and high end bracket the measured number.
By their numbers in this assay, from the lowest: compounds 2, 4 and 3 (each within the scatter of the next).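

In this assay the aromatic nitrogen takes 1,3-benzothiazol-2-yl, a group with a five-membered aromatic ring bearing hetero atoms and with hydrogen-bond acceptors, without a step beyond the scatter: a 1.6-fold higher number from compound 2 to compound 4 (0.19 log units; within the scatter) and a 1.2-fold lower number from compound 3 to compound 4 (0.07 log units; within the scatter) are both within it. Across the three groups now measured at this place, no separation appears. No evidence bears on this result.

Still open, on these data alone, is whether an amine, a carboxylic acid or a longer alkyl chain on this aromatic nitrogen would give a step beyond the scatter.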